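Trimming the Side Chain of Compound 2

The compounds below may be only part of what the source reports. "The series", "measured", "known", "first", "only" and "open" are said of these compounds alone.

Compound 1 `Cn1c(Cc2nn(CCCO[Si](C)(C)C(C)(C)C)c(=O)c3ccccc23)nnc1SCCCCCCCC(=O)Nc1ccc(Cl)cc1Cl` was tested in an assay on NK92 cells for inhibition of interleukin-15 (Homo sapiens), read by AlphaScreen, with stated times of 30 min and 1 h (on this read-out higher numbers stand for weaker inhibition and lower numbers for stronger inhibition), where compound 1 gives > 30000 nM, a limit of the assay rather than a number. Compound 2 `Cn1c(Cc2nn(CCC(=O)O)c(=O)c3ccccc23)nnc1SCCCCCCCC(=O)Nc1ccc(Cl)cc1Cl` gives > 30000 nM in this assay, again a limit. The step that the two limits leave unreadable from compound 1 to compound 2 cannot be read, as both values sit at the limit of > 30000 nM in this assay, at which 2 of the 2 values shown sit. Compound 3 `Cn1c(Cc2n[nH]c(=O)c3ccccc23)nnc1SCCCCCCCC(=O)Nc1ccc(Cl)cc1Cl` differs from compound 2 by hydrogen in place of 2-carboxyethyl on an aromatic nitrogen. Within the data shown here, the single measured step is unreadable, so in this assay compound 3 is expected to remain at the limit, with an expected step of a number no higher from compound 2 to compound 3 (the limit leaves the size open). Compound 3 is estimated at 30000 nM, within 10000 nM to 100000 nM.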

Compound 3, half-maximal inhibitory concentration: 20000 nM
For compound 3 the middle estimate is 1.5-fold (0.18 log units) above the measured one; the measured number falls inside the stated range.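

Of the three, only compound 3, with hydrogen on this aromatic nitrogen, gives a number in this assay rather than a limit. Its gain has only a floor, and a small one: the change reads as an at least 1.5-fold lower number from compound 2 to compound 3 (0.17 log units; that floor lies within the scatter), and as an at least 1.5-fold lower number from compound 1 to compound 3 (0.17 log units; that floor lies within the scatter). The values of compound 1 and compound 2 are limits, not numbers: the limit of > 30000 nM in this assay, at which 2 of the 3 values shown sit.

From the compounds shown here alone, whether a methyl group or a short chain ending in an amine on this nitrogen would also give a number in this assay stays open.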